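Amino in Place of the Amide Hydrogen in a Glutarimide Pair

A few compounds are considered here, and "the series" means these few. Any claim that something is new, unique, unknown or untested is made for them only; others in the source may bear on it.

Of the compounds shown here, two sharing a six-membered ring core have been tested in a functional assay on the whole organism (strain Swiss albino) for inhibition, with Mus musculus as the target, in the maximal electroshock model, with a stated time of 2 h, at a dose of 25 mg/kg by the intraperitoneal route; a lower number here means less inhibition, a higher number more inhibition at the dose given (going by the name of the read-out). Compound 1 `CN1C(=O)C(c2ccccc2)CC(c2ccccc2)C1=O` carries a methyl group on the ring nitrogen and two unsubstituted phenyl groups; in this assay compound 1 gives 69.1%. Compound 2 `O=C1NC(=O)C(c2ccccc2Cl)CC1c1ccccc1Cl` bears a hydrogen on the ring nitrogen and a chlorine on each phenyl ring; in this assay compound 2 gives 58.3%. Of the two numbers, compound 2 stands lowest, and the gap to compound 1 lies beyond the usual scatter, though the two differ in more than one place, so the values alone cannot say which change matters.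

Compound 3 `NN1C(=O)C(c2ccccc2Cl)CC(c2ccccc2Cl)C1=O` has not yet been measured. It differs from compound 2 in a single respect: amino in place of hydrogen on an amide-type nitrogen in a ring.

For the measured compounds named here, no measured pair shows the effect of this exact exchange, so the expectation rests only on the two values shown. The step from compound 2 to compound 3 is expected to be modest and upward, a number 4.7 percentage points higher from compound 2 to compound 3 (within the scatter), likely within the scatter. Compound 3 is therefore estimated to give 63%, with a range from 45% to 80%.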

Compound 3, a percentage reported as inhibition, in the whole organism at one dose (the size of the read-out at that dose, not a potency): 73.3%
For compound 3 the middle estimate is 10.3 percentage points below the measured one, and the stated range covers the measured number.
By their numbers in this assay, from the lowest: compound 2; then compounds 1 and 3 (each within the scatter of the next).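

In this assay, amino in place of hydrogen on an amide-type nitrogen in a ring gives a number 15 percentage points higher from compound 2 to compound 3 (beyond the scatter). This is the first comparison here that changes one place only: both 2-chlorophenyl groups stay the same, so the difference can be traced to the group on the ring nitrogen, and the amide hydrogen is shown not to be required for inhibition in this model at this dose. No measurement shown gives a reason for the rise.

As far as these compounds go, it remains open whether the gain belongs to amino specifically or would also appear with another group on this nitrogen, such as a hydroxyl group, an acetyl group or a longer chain like n-propyl, and a methyl group cannot settle this yet, since compound 1 carries methyl alongside unsubstituted phenyl groups. The read-out also comes from a single dose and time, so it describes the size of the effect under those conditions, not potency, and leaves open whether the step would hold at other doses.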